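Solubility in the series: isobutyl to benzyl

This account rests on a few compounds, and the source may have more. Where it says the series, first, only, none or still open, it means among the compounds named here.

In a physicochemical assay for solubility, in phosphate buffer, with a stated time of 18 h (a lower number here means a less soluble compound, a higher number a more soluble compound), compound 1 `N#Cc1c(N)nc2nc(C3CC3)ncc2c1N` gives 23000 nM and compound 2 `CC(C)Cc1ncc2c(N)c(C#N)c(N)nc2n1` gives 268000 nM, the higher of the two numbers. Among the measured compounds shown here, the only measured step, a 12-fold higher number from compound 1 to compound 2 (1.07 log units; beyond the scatter), is large and beyond the scatter. It is isobutyl in place of cyclopropyl on an aromatic carbon.

Compound 3 `N#Cc1c(N)nc2nc(Cc3ccccc3)ncc2c1N` differs from compound 2 by phenyl in place of isopropyl on a saturated chain carbon bound to an aromatic carbon, or, cut one bond further out, isobutyl to benzyl. The measured step bears on this change only loosely, since neither compound 1 nor compound 2 carries phenyl. It shows that one change of this group moved the number in this assay by a large amount, but it does not settle the direction here. The direction is therefore a judgement, with a lower number expected and a wide margin kept.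

The expected change is a 5.4-fold lower number from compound 2 to compound 3 (0.73 log units; beyond the scatter), smaller than the measured step. For compound 3 the estimated value is 50000 nM, with an expected range from 12000 nM to 180000 nM.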

Compound 3, solubility: 13000 nM
Compound 3: the middle estimate sits 3.8-fold (0.59 log units) above what was measured; low and high end bracket the measured number.
By their numbers in this assay, from the lowest: compounds 3 and 1 (each within the scatter of the next); then compound 2.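

In this assay, the exchange on a saturated chain carbon bound to an aromatic carbon now has a direct reading, and phenyl in place of isopropyl goes with a large drop in the number (a 21-fold lower number from compound 2 to compound 3 (1.31 log units; beyond the scatter)), a direction that the earlier pair could not give. The comparison of benzyl with cyclopropyl on the aromatic carbon gives no separation (a 1.8-fold lower number from compound 1 to compound 3 (0.25 log units; within the scatter)), so compound 2, with isobutyl, is the only one of the three that stands apart, with the highest number in the set, and its steps to the other two both lie beyond the scatter. No measurement at hand offers an explanation for either step.

Three groups cannot show whether the high number belongs to isobutyl alone or extends to a longer chain such as n-pentyl or to a branched group such as neopentyl. Going by these compounds, it also remains open how the number would respond to a benzyl group carrying an amine or a carboxylic acid on its phenyl ring, or to a saturated ring such as cyclohexyl in place of that phenyl.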